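Opening the Ring: From Compound 2 to Compound 4

The source may report more compounds than this note shows. Statements on the series, on what has been measured and on what is new or still open speak of the compounds shown alone.

Three compounds have numbers in an assay on nucleic acid for inhibition of Nucleic Acid, read by fluorescence, tested at 100 uM; on this read-out lower numbers stand for less inhibition and higher numbers for more inhibition at the one concentration tested (going by the name of the read-out):
compound 1 `CCOC(=O)C1CCCN(Cc2cn(C3CCCCC3OC(=O)COc3ccccc3)nn2)C1` gives 21%
compound 2 `CCOC(=O)C1CCCN(Cc2cn(C3CCCCC3O)nn2)C1` gives 16%
compound 3 `CCOC(=O)C1CCCN(Cc2cn(C3CCCCC3OC(=O)c3ccccc3)nn2)C1` gives 11%

Compound 2 stands in the middle of these three numbers, with the step of a number 5 percentage points lower from compound 1 to compound 2 (within the scatter) and the step of a number 5 percentage points lower from compound 2 to compound 3 (within the scatter) both within the scatter, as is the step of a number 10 percentage points lower from compound 1 to compound 3 (within the scatter). Compound 4 `CCCCC(O)Cn1cc(CN2CCCC(C(=O)OCC)C2)nn1` differs from compound 2 in one place: 2-hydroxyhexyl in place of 2-hydroxycyclohexyl on an aromatic nitrogen. Among the compounds with values here, none of the measured steps touches this part of the molecule; they all vary the group on the oxygen on the saturated carbon or on the carbonyl carbon, and none of them moves beyond the scatter. Within the data shown here, no measured step therefore bears directly on this change, and no shift beyond the scatter is expected in this assay, so the step of no change at the digits printed from compound 2 to compound 4 (within the scatter) is estimated to be small. Compound 4 is expected to give about 16%, between 4% and 30%.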

Compound 4, a percentage reported as inhibition, at one concentration (the size of the read-out at that concentration, not a potency): 53%
For compound 4 the middle estimate is 37 percentage points below the measured one; measured number outside the range, above it.
By their numbers in this assay, from the lowest: compounds 3, 2 and 1 (each within the scatter of the next); then compound 4.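

In this assay, within the data shown here, the group on the aromatic nitrogen matters: a number 37 percentage points higher from compound 2 to compound 4 (beyond the scatter) is the only step so far beyond the scatter, and it comes with the ring of 2-hydroxycyclohexyl gone while the counts of heavy atoms, donors and acceptors stay the same. The earlier compounds shown here varied only the group on the oxygen and showed no step of this kind. Nothing shown bears on the reason for this step. The compounds shown leave open whether a longer chain, or an amine in place of the hydroxyl, would hold this number. They also leave open whether a benzoyl group on the oxygen of compound 4 would change it.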